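The source may report more compounds than this note shows. Statements on the series, on what has been measured and on what is new or still open speak of the compounds shown alone.

Compound 1 `CCOC(=O)c1sc(-c2ccccc2)nc1N1CCC(NCc2ccc(OCc3ccccc3)cc2)CC1`: 18.4%
Compound 2 `CCOC(=O)c1sc(-c2ccncc2)nc1N1CCC(NCc2ccc(F)cc2)CC1`: 17.5%

In an ADME assay on RAW264.7 cells (Mus musculus) for cytotoxicity, read by MTT assay, with a stated time of 72 h, tested at 50 uM (on this read-out lower numbers stand for less inhibition and higher numbers for more inhibition at the one concentration tested (going by the name of the read-out)), compound 2 gives 17.5%, while compound 1 gives 18.4%; the two numbers lie within the scatter of each other, so compound 2 stands level with compound 1 here. Compound 3 `CCOC(=O)c1sc(-c2ccncc2)nc1N1CCC(NCc2ccc(OCc3ccccc3)cc2)CC1` keeps the core of compound 2 and differs by benzyloxy in place of fluoro on an aromatic carbon. For the measured compounds named here, no measured pair isolates this change, yet compound 1 already carries the entering benzyloxy and shows no separation from compound 2. Compound 3 is therefore expected to show no step beyond the scatter, a number 1.5 percentage points higher from compound 2 to compound 3 (within the scatter). Compound 3 in this assay is estimated at 19%, within 8% to 32%.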

Compound 3, a percentage reported as inhibition, at one concentration (the size of the read-out at that concentration, not a potency): 8.04%
Compound 3: the middle estimate sits 11 percentage points above what was measured; the measured number falls inside the stated range.
By their numbers in this assay, from the lowest: compounds 3, 2 and 1 (each within the scatter of the next, the first and the last beyond it).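

In this assay benzyloxy in place of fluoro on an aromatic carbon gives a number 9.5 percentage points lower from compound 2 to compound 3 (within the scatter) and so leaves this position without a step that can be told from the scatter. For the compounds shown here, with benzyloxy kept, pyridin-4-yl in place of phenyl gives a number 10.4 percentage points lower from compound 1 to compound 3 (beyond the scatter) and is the only step here beyond the scatter, though a modest one. No supporting data explain this step.

Going by these compounds, whether that step would hold with fluoro in place of benzyloxy stays open. So does what an amine or a methoxy group would give on that aromatic carbon.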